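The compounds below may be only part of what the source reports. "The series", "measured", "known", "first", "only" and "open" are said of these compounds alone.

Series notes, cytotoxicity branch. Among the measured compounds shown here, the three compounds measured so far share one core and differ only in the aryl group at its end: compound 1 `CC(C)Oc1cccc(-c2ccc(C(=O)N(Cc3cccc(OCCCCCC(=O)O)c3)C(C)C)cc2)c1`, compound 2 `CC(C)N(Cc1cccc(OCCCCCC(=O)O)c1)C(=O)c1ccc(-c2ccc3[nH]ccc3c2)cc1` and compound 3 `CC(C)N(Cc1cccc(OCCCCCC(=O)O)c1)C(=O)c1ccc(-c2cccc(OC(F)(F)F)c2)cc1`. In an ADME assay on BJ cells (Homo sapiens) for cytotoxicity, read by CellTiter-Glo and resazurin assay, with a stated time of 72 h (on this read-out higher numbers stand for an effect only at larger amounts of compound and lower numbers for an effect already at smaller amounts), compound 1 gives > 26000 nM, which is a limit of the assay and not a number. Compound 2 likewise returns only the limit > 26000 nM. Compound 3 also sits at the limit with > 26000 nM. Consequently a step that the two limits leave unreadable from compound 1 to compound 2, a step that the two limits leave unreadable from compound 1 to compound 3 and a step that the two limits leave unreadable from compound 2 to compound 3; the whole picture so far is the limit of > 26000 nM in this assay, at which 3 of the 3 values shown sit, so compound 1 cannot be placed relative to the others beyond saying that none of them shows an effect within the tested range.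

The next compound, compound 4 `CC(C)N(Cc1cccc(OCCCCCC(=O)O)c1)C(=O)c1ccc(-c2cccc(C(F)(F)F)c2)cc1`, differs from compound 1 by trifluoromethyl in place of isopropoxy on an aromatic carbon. For the measured compounds named here, no measured step bears on it in a readable way, since every step to hand is capped at the limit. The expectation is that compound 4 again shows no effect within the tested range, so that a step that the limit leaves unreadable from compound 1 to compound 4 is expected to remain unreadable against the limit. Compound 4 is therefore estimated at 40000 nM, within 15000 nM to 100000 nM, most likely reported as a limit.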

Compound 4, half-maximal effective concentration: > 26000 nM
Compound 4: only a limit was reported; the forecaster's own chance of this, stated with the estimate: 85%; the middle value lies beyond the limit too.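

In this assay compound 4 gives > 26000 nM, a limit of the assay and not a number. Its steps from compound 1, compound 2 and compound 3 therefore cannot be read. The compounds shown leave open whether any aryl group at this end gives an effect within the tested range: the limit of > 26000 nM in this assay, at which 4 of the 4 values shown sit.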